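The source may report more compounds than this note shows. Statements on the series, on what has been measured and on what is new or still open speak of the compounds shown alone.

Measured so far in a functional assay on PANC-1 cells (Homo sapiens) for inhibition, read by MTT assay, with a stated time of 72 h; a lower number here means a stronger inhibitor, a higher number a weaker inhibitor:
compound 1 `Cc1cnc(C(=O)Nc2cc(Cl)cc3cccnc23)cn1` gives 1770 nM.
compound 2 `NCCOc1cc(NC(=O)c2cnccn2)c2ncccc2c1` reaches only the assay limit, > 10000 nM.
compound 3 `Cc1cnc(C(=O)Nc2cc(OCCNC(=O)OC(C)(C)C)cc3cccnc23)cn1` gives 2170 nM.

Compound 3 has the higher of the two numbers in this assay, with compound 1 sitting within the scatter of it. The value of compound 2 is a limit, not a number (the limit of > 10000 nM in this assay, at which 1 of the 3 values shown sits). Compound 4 `Cc1cnc(C(=O)Nc2cc(OCCN)cc3cccnc23)cn1` is compound 3 with hydrogen in place of tert-butoxycarbonyl on an amine nitrogen. Among the measured compounds shown here, no measured pair covers this change directly. Compound 2 carries 2-aminoethyl on the same core; its value in this assay is a limit. The step from compound 3 to compound 4 in this assay is therefore expected to run toward a weaker inhibitor, about a 2.3-fold higher number from compound 3 to compound 4 (0.36 log units; beyond the scatter). Compound 4 is estimated at 5000 nM, range 1500 nM to 15000 nM, with a fair chance that only a limit is reported.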

Compound 4, half-maximal inhibitory concentration: > 10000 nM
Compound 4 was reported as a limit; the forecaster's own chance of this, stated with the estimate: 35%; middle value at least 2.0-fold (0.30 log units) from the limit.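

In this assay, hydrogen in place of tert-butoxycarbonyl on the amine nitrogen gives an at least 4.6-fold higher number from compound 3 to compound 4 (0.66 log units; beyond the scatter), so the free 2-aminoethyl chain is clearly less well tolerated than its protected form. Against chloro on the shared core, 2-aminoethoxy gives an at least 5.6-fold higher number from compound 1 to compound 4 (0.75 log units; beyond the scatter). Compound 4 is reported only as a limit, as is compound 2: the limit of > 10000 nM in this assay, at which 2 of the 4 values shown sit.

Going by these compounds, the step between compound 2 and compound 4 cannot be read, so the effect of the methyl on an aromatic carbon remains open. Also open, on these data alone, is whether an acetamide, a dimethylamino group or a longer chain would return a measurable number.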